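The source may hold more compounds than are shown below. What is called first, only, known or untested is meant among the compounds shown, and "the series" means these compounds.

Measured so far in an ADME assay on BE(2)-C cells (Homo sapiens) for cytotoxicity, read by MTT assay, with a stated time of 72 h; on this read-out higher numbers stand for weaker inhibition of growth and lower numbers for stronger inhibition of growth:

Compound 1 `CCCCNC(=O)C1C(C(=O)O)[C@@H]2CC[C@H]1O2`: 10000 nM
Compound 2 `CCOC(=O)c1cn[nH]c1NC(=O)C1C(C(=O)O)[C@@H]2CC[C@H]1O2`: 10000 nM
Compound 3 `O=C(O)C1C(C(=O)Nc2ccccc2)[C@H]2CC[C@@H]1O2`: 10000 nM

Compound 1 stands level with compounds 2 and 3 on these numbers; its nearest neighbour on the value is compound 2 and its furthest is compound 3, and neither gap leaves the scatter. For the measured compounds named here, the only measured step is no change at the digits printed from compound 1 to compound 3 (within the scatter), which exchanges the butyl on the amide-type nitrogen for phenyl and does not move the read-out.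

Compound 4 `O=C(O)CCCCCCCNC(=O)C1C(C(=O)O)[C@@H]2CC[C@H]1O2` is the next member. Its change from compound 1 is 3-carboxypropyl in place of hydrogen on a saturated chain carbon, four bonds along the chain from an amide-type nitrogen; cut one bond further out, the same change reads methyl to 4-carboxybutyl. Going by the values given here, no measured step bears directly on a chain carbon extended this way; the one step known, from butyl to phenyl, left the value unchanged, and all three measured compounds sit at a single value. The expected step from compound 1 to compound 4 is therefore none beyond the scatter, no change at the digits printed from compound 1 to compound 4 (within the scatter). Compound 4 is expected to give 10000 nM, within 5000 nM to 20000 nM.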

Compound 4, concentration for 50% growth inhibition: 10000 nM
Compound 4: middle estimate and measured number agree at the digits printed; the range from low to high includes it.
By their numbers in this assay, from the lowest: compounds 1, 2, 3 and 4 (each within the scatter of the next).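

In this assay the series shows no change at the digits printed from compound 1 to compound 4 (within the scatter) and so extends the picture from an exchange on the amide-type nitrogen to the saturated chain itself. At this carbon, four bonds along the chain from an amide-type nitrogen, 3-carboxypropyl in place of hydrogen adds 6 heavy atoms and a carboxylic acid without moving the value out of the scatter. No measurement on hand accounts for this result.

The compounds shown leave open whether any change on this chain can separate a compound from the single value shared so far. An amine in place of the 3-carboxypropyl, or a longer chain ending in a hydroxamic acid, would test this against compound 4.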